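Swapping Neopentyl for an Oxanyl Ring on the Amide Arm

A few compounds are considered here, and "the series" means these few. Any claim that something is new, unique, unknown or untested is made for them only; others in the source may bear on it.

Three measured compounds share one core and differ only in the group carried on the amide arm. Compound 1 holds a 4-fluorophenyl group there `Cc1nc2cc(C(=O)NCc3ccc(F)cc3)nn2c(-c2cc(F)c3c(c2C)CCCO3)c1[C@H](OC(C)(C)C)C(=O)O`, compound 2 adds propyl in place of hydrogen on an aromatic carbon of that group `CCCc1cc(CNC(=O)c2cc3nc(C)c([C@H](OC(C)(C)C)C(=O)O)c(-c4cc(F)c5c(c4C)CCCO5)n3n2)ccc1F`, and compound 3 carries neopentyl instead `Cc1nc2cc(C(=O)NCCC(C)(C)C)nn2c(-c2cc(F)c3c(c2C)CCCO3)c1[C@H](OC(C)(C)C)C(=O)O`. In an ADME assay on MT2 cells (Homo sapiens) for cytotoxicity (on this read-out higher numbers stand for lower toxicity in this test and lower numbers for higher toxicity in this test), compound 1 gives > 40000 nM, which is a limit of the test and not a number. Compound 2 also reaches a limit, > 20000 nM. Compound 3 likewise sits at a limit, > 40000 nM, so its standing is known only as at or beyond that boundary; two of the three values rest at the limit of > 40000 nM in this assay, at which 2 of the 3 values shown sit, and one at the limit of > 20000 nM in this assay, at which 1 of the 3 values shown sits. The steps a step that the two limits leave unreadable from compound 1 to compound 2, a step that the two limits leave unreadable from compound 1 to compound 3 and a step that the two limits leave unreadable from compound 2 to compound 3 therefore cannot be sized.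

Compound 4 `Cc1nc2cc(C(=O)NCC3CCOCC3)nn2c(-c2cc(F)c3c(c2C)CCCO3)c1[C@H](OC(C)(C)C)C(=O)O` changes the same arm: oxan-4-yl in place of neopentyl on a saturated chain carbon bound to an amide-type nitrogen. The neighbouring steps bear on it only in that every variation of this arm so far has left toxicity unreadable at a limit. The expected step is thus a number no higher from compound 3 to compound 4 (the limit leaves the size open), none beyond the usual scatter. Compound 4 is expected to give 40000 nM, within a range from 20000 nM to 80000 nM.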

Compound 4, half-maximal cytotoxic concentration: > 40000 nM
Compound 4 was reported as a limit (the forecaster's own chance of this, stated with the estimate: 85%); the middle value lies on the limit itself.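

Compound 4 gives > 40000 nM, which is a limit of the test and not a number. Compound 1, compound 2 and compound 3 also rest at limits, so none of their steps to compound 4 can be read. The compounds shown leave open how far each one lies past its limit, and whether these amide arm groups differ in cytotoxicity at all.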